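Compound 2 without a number, compound 3 still to come

The compounds below may be only part of what the source reports. "The series", "measured", "known", "first", "only" and "open" are said of these compounds alone.

Compound 1 `COc1cc(C(=O)N2CC(C)C(O)CC2C)cc2nc(NCc3cccc(Cl)c3)oc12` gives 127 nm/s; "not determined" (no result reported) (2 entries) as its entries
Compound 2 `CCC1CC(O)C(C)CN1C(=O)c1cc(OC)c2oc(NCc3cccc(Cl)c3)nc2c1` gives "not determined" (no result reported) as its entry

In an ADME assay on Caco-2 cells (Homo sapiens) for permeability, read by LC-MS, in the apical to basolateral direction, with a stated time of 2 h (a lower number here means that the compound crosses the layer more slowly, a higher number that the compound crosses the layer faster), compound 2 has no single number to stand on, since its only entry reads "not determined" (no result reported) and nothing more. The nearest figure comes from compound 1, whose record is the several entries of compound 1 in this assay, 127 nm/s; "not determined" (no result reported) (2 entries) and so holds one number and one empty result.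

Compound 3 `COc1cc(C(=O)N2CC(C)C(O)CC2CCO)cc2nc(NCc3cccc(Cl)c3)oc12` is the next to be measured. The change hydroxy in place of hydrogen on a saturated chain carbon, two bonds along the chain from a saturated ring carbon is hydroxy in place of hydrogen on a saturated chain carbon, two bonds along the chain from a saturated ring carbon, so that ethyl becomes 2-hydroxyethyl.

Among the compounds with values here, no measured step shows what such a change does, so the expectation is a judgement and a loose one. Within the data shown here, a moderate fall in this assay is expected, somewhat beyond the usual scatter, taken from the one number that compound 1 gives at 127 nm/s; "not determined" (no result reported) (2 entries) as the only anchor.

For compound 3 the expected value is 45 nm/s with an estimated range from 12 nm/s to 120 nm/s in this measurement.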

Compound 3, apparent permeability: 9.4 nm/s
Compound 3: the middle estimate sits 4.8-fold (0.68 log units) above what was measured; measured number below the stated range.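

In this assay, within the data shown here, compound 3 gives 9.4 nm/s, but compound 2, from which it differs in one place, has no single number there, so no step between compound 2 and compound 3 can be read. The compounds shown leave open what 2-hydroxyethyl in place of ethyl does to this read-out.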